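Selenocyanate carbamates: ethyl to phenyl on the carbamate oxygen

The source may report more compounds than this note shows. Statements on the series, on what has been measured and on what is new or still open speak of the compounds shown alone.

Working notes on a pair of carbamates carrying the same selenocyanate-bearing core. Compound 1 `C=CCOC(=O)Nc1ccc([Se]C#N)cc1` is the allyl carbamate; in an ADME assay on 184B5 cells (Homo sapiens) for cytotoxicity, read by MTT assay, with a stated time of 72 h (on this read-out higher numbers stand for weaker inhibition of growth and lower numbers for stronger inhibition of growth), compound 1 gives 5000 nM. Compound 2 `CCOC(=O)Nc1ccc([Se]C#N)cc1` is the ethyl analogue; in this assay compound 2 gives 5500 nM. Going by the values given here, the only step so far, a 1.1-fold higher number from compound 1 to compound 2 (0.04 log units; within the scatter), is small, so the two numbers cannot be ranked against each other. Compound 2 thus stands at one end of two numbers that lie within the scatter of each other.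

Compound 3 `N#C[Se]c1ccc(NC(=O)Oc2ccccc2)cc1` is the next member to be measured in this assay. The change from compound 2 is phenyl in place of ethyl on an oxygen next to a carbonyl group. Among the compounds with values here, the one measured step bears on it only loosely: it also altered the group on the same oxygen, and a 1.1-fold higher number from compound 1 to compound 2 (0.04 log units; within the scatter) produced no movement beyond the scatter. The present change is larger, adding a ring where the earlier step exchanged chain groups, so the precedent is thin. The working expectation is a step of a 1.1-fold lower number from compound 2 to compound 3 (0.04 log units; within the scatter), that is, no movement beyond the scatter, with a wide range to cover the weak precedent. Compound 3 is therefore estimated at 5000 nM in this assay, between 2000 nM and 12500 nM.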

Compound 3, concentration for 50% growth inhibition: 400 nM
Estimate against measurement, compound 3: 13-fold (1.10 log units) above, and the stated range ends above it.
By their numbers in this assay, from the lowest: compound 3; then compounds 1 and 2 (each within the scatter of the next).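

In this assay the group on the oxygen next to a carbonyl group proves able to shift the read-out: phenyl in place of ethyl gives a 14-fold lower number from compound 2 to compound 3 (1.14 log units; beyond the scatter) and phenyl in place of allyl gives a 13-fold lower number from compound 1 to compound 3 (1.10 log units; beyond the scatter) on the same core. The exchange between the two chain groups gave no separable difference, so this position responds to the entry of phenyl, a six-membered aromatic ring of carbon only, and not to every change made there. Compound 3 has the lowest number of the three, with its steps to both other compounds beyond the scatter, and thus shows the strongest inhibition of growth in this small set.

From the compounds shown here alone, whether the shift needs an aromatic ring on this oxygen or any ring will do stays open, as does whether a longer chain, a cyclohexyl ring, a benzyl group or a phenyl carrying a chlorine or a methoxy group would follow compound 3 or the chain carbamates. Nothing at hand explains why phenyl gives this shift in growth inhibition.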